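From Cyclopropyl to Propyl on the Same Nitrogen

The source may hold more compounds than are shown below. What is called first, only, known or untested is meant among the compounds shown, and "the series" means these compounds.

Of the compounds shown here, three have been tested in a functional assay on SW480 cells (Homo sapiens) for inhibition, read by luminescence and resazurin assay, with a stated time of 3 days; a lower number here means a stronger inhibitor, a higher number a weaker inhibitor. Compound 1 `CCCNc1nc(NCc2ccc(NC(=O)c3ccc(F)cc3)cc2)c2ccccc2n1` gives 2000 nM. Compound 2 `CCNc1nc(NCc2ccc(C(=O)Nc3ccc(F)cc3)cc2)c2ccccc2n1` gives 2500 nM. Compound 3 `O=C(Nc1ccc(F)cc1)c1ccc(CNc2nc(NC3CC3)nc3ccccc23)cc1` gives 2600 nM, the highest of the three numbers, although its gap to compound 2 and to compound 1 is within the scatter, so none of the three can be called stronger or weaker than another.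

The next compound, compound 4 `CCCNc1nc(NCc2ccc(C(=O)Nc3ccc(F)cc3)cc2)c2ccccc2n1`, differs from compound 3 in one place: propyl in place of cyclopropyl on a nitrogen on an aromatic ring. Among the measured compounds shown here, only one measured step touches the same nitrogen, that from compound 2 to compound 3, where cyclopropyl replaced ethyl; it read a 1.0-fold higher number from compound 2 to compound 3 (0.02 log units; within the scatter). For the measured compounds named here, compound 1 also carries propyl on that nitrogen, but its amide is built the other way round, so it differs from compound 4 in two places and offers no single step to lean on; its value simply sits close to those of compound 2 and compound 3.

Going by the values given here, because the one step between small alkyl groups at this nitrogen, a 1.0-fold higher number from compound 2 to compound 3 (0.02 log units; within the scatter), stayed within the scatter, the expected step in this assay from compound 3 to compound 4 is also none beyond the scatter, a 1.1-fold lower number from compound 3 to compound 4 (0.05 log units; within the scatter). Compound 4 is therefore estimated at 2300 nM, with a range from 1100 nM to 4800 nM.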

Compound 4, half-maximal inhibitory concentration: 1600 nM
Compound 4: the middle estimate sits 1.4-fold (0.16 log units) above what was measured; measured number inside the range.
By their numbers in this assay, from the lowest: compounds 4, 1, 2 and 3 (each within the scatter of the next).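

In this assay, opening the cyclopropyl ring to a propyl chain on this nitrogen gives a 1.6-fold lower number from compound 3 to compound 4 (0.21 log units; within the scatter) and extending ethyl to propyl gives a 1.6-fold lower number from compound 2 to compound 4 (0.19 log units; within the scatter). This nitrogen has now carried ethyl, cyclopropyl and propyl without any step leaving the scatter, so neither the ring nor the extra carbon of propyl over ethyl shows a readable effect here. Turning the amide round, with propyl held on the nitrogen, gives a 1.3-fold lower number from compound 1 to compound 4 (0.10 log units; within the scatter), so this new pair shows that the direction of the amide also makes no readable difference in this one setting, and no measurement at hand offers an explanation for any of these readings.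

The compounds shown leave open what a much longer chain such as hexyl, or a chain ending in an amine or a carboxylic acid, would do on this nitrogen. They also leave open whether the reversed amide would read the same with ethyl or cyclopropyl on the nitrogen, since that direction appears here only with propyl.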